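Changing the aryl group on a ring nitrogen of the shared core

The compounds below may be only part of what the source reports. "The series", "measured", "known", "first", "only" and "open" are said of these compounds alone.

Of the compounds shown here, three of one shared core have been measured in an in vitro functional assay on cells for antagonist activity at metabotropic glutamate receptor 1 (Homo sapiens), read by FLIPR and calcium flux; on this read-out lower numbers stand for stronger inhibition and higher numbers for weaker inhibition. Compound 1 `Cc1nc2c(cnn2-c2ccccc2)c(=O)n1-c1cccc(Cl)c1` reaches only the limit of this assay, > 100000 nM. Compound 2 `Cc1nc2c(cnn2-c2ccccc2)c(=O)n1N1CCCCC1` gives 91 nM, and compound 3 `Cc1ccccc1-n1ncc2c(=O)n(-c3ccc(Cl)cc3)c(C)nc21` gives 350 nM, the highest of the two numbers; the gap from compound 2 to compound 3 lies beyond the scatter. Within the data shown here, the only single-point step measured so far, an at least 1000-fold lower number from compound 1 to compound 2 (3.04 log units; beyond the scatter), concerns a different position of the core, and it is marked by the limit of > 100000 nM in this assay, at which 1 of the 3 values shown sits.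

Compound 4 `Cc1nc2c(cnn2-c2cccc(Cl)c2)c(=O)n1-c1ccc(Cl)cc1` differs from compound 3 by 3-chlorophenyl in place of 2-methylphenyl on an aromatic nitrogen. Among the measured compounds shown here, no measured step touches this aryl group, so the earlier step gives no guide to its direction or size. The expectation for compound 4 is therefore a number close to that of compound 3, with a wide band: the step of a 1.4-fold higher number from compound 3 to compound 4 (0.15 log units; within the scatter) is expected to stay within the scatter. Compound 4 is estimated at 500 nM in this assay, expected to fall between 100 nM and 3000 nM.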

Compound 4, half-maximal inhibitory concentration: 220 nM
Compound 4: middle estimate off by 2.3-fold (0.36 log units), on the high side; the range from low to high includes it.
By their numbers in this assay, from the lowest: compound 2; then compounds 4 and 3 (each within the scatter of the next). At a limit, above all of these: compound 1.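

The aryl group on an aromatic nitrogen of the five-membered aromatic ring now has a measured step of its own, a 1.6-fold lower number from compound 3 to compound 4 (0.20 log units; within the scatter), so this assay does not tell these two compounds apart. With the rest of the molecule held fixed, 2-methylphenyl and 3-chlorophenyl, each a six-membered aromatic ring of carbon only, are interchangeable at this position, though this rests on a single pair. Nothing measured here gives a reason for this result.

The compounds shown leave open whether this position accepts anything other than a substituted phenyl ring, such as a saturated cyclohexyl ring or a longer chain like n-butyl. Going by these compounds, it also remains open what a carboxylic acid or an amine on this aryl ring would do to the number.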